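Adding a Hydroxy Group to a Non-Cytotoxic Nucleoside

A few compounds are considered here, and "the series" means these few. Any claim that something is new, unique, unknown or untested is made for them only; others in the source may bear on it.

Among the measured compounds shown here, compound 1 `Nc1ncnc2c1ncn2[C@H]1C=C[C@@H](CO)O1` is the first of two measured compounds. In a functional assay on C3H/3T3 cells (Mus musculus) for cytotoxicity (a lower number here means that less compound is tolerated, a higher number that more compound is tolerated), compound 1 reaches only the limit of the assay, > 50000 nM, so no number is known for it. Compound 2 `Cc1cccc2c1OP(=O)(OCC1CCC(n3cnc4c(O)ncnc43)O1)OC2` carries a larger framework around a related core. In this assay compound 2 likewise gives only a limit, > 50000 nM, not a number. Both known values sit at the same edge: the limit of > 50000 nM in this assay, at which 2 of the 2 values shown sit, so compound 2 stands nowhere on a scale, only at that edge. The unmeasured compound 3 `Cc1cccc2c1OP(=O)(OCC1CC(O)C(n3cnc4c(O)ncnc43)O1)OC2` differs from compound 2 in one place: hydroxy in place of hydrogen on a saturated ring carbon. For the measured compounds named here, no step between measured compounds exists to guide the size. With both known values at the limit, the expected step of a number no higher from compound 2 to compound 3 (the limit leaves the size open) is none beyond the usual scatter. Compound 3 is therefore most likely to return a limit again, and is expected to give about 50000 nM, within 20000 nM to 200000 nM.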

Compound 3, minimum cytotoxic concentration in the C3H/3T3 assay: > 50000 nM
Compound 3: only a limit was reported; the forecaster's own chance of this, stated with the estimate: 85%; the middle value lies on the limit itself.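

Compound 2 and compound 3 both give only a limit in the C3H/3T3 assay and not a number, so the step between them cannot be read. In a physicochemical assay for lipophilicity (a lower number here means a more polar compound, a higher number a more lipophilic compound), compound 2 gives 0.14 and compound 3 gives 0.078 within the usual scatter of each other. What actual number any of these compounds would reach in the C3H/3T3 assay stays open.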